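Swapping a pyridinyloxy group for an imidazolyl ring

The source may report more compounds than this note shows. Statements on the series, on what has been measured and on what is new or still open speak of the compounds shown alone.

Three compounds have numbers in a functional assay for inhibition of sodium/hydrogen exchanger (Oryctolagus cuniculus); on this read-out lower numbers stand for stronger inhibition and higher numbers for weaker inhibition. Compound 1 `Cc1cc(-c2ccc(Cl)cc2)c(S(C)(=O)=O)cc1C(=O)N=C(N)N` gives 45 nM, compound 2 `Cc1cc(Sc2ccc(Cl)cc2)c(S(C)(=O)=O)cc1C(=O)N=C(N)N` gives 19 nM and compound 3 `CS(=O)(=O)c1cc(C(=O)N=C(N)N)c(Cl)cc1Oc1cccnc1` gives 52 nM. Compound 3 stands highest of the three, within the scatter of compound 1 and beyond the scatter of compound 2. Among the measured compounds shown here, the only measured step, a 2.4-fold lower number from compound 1 to compound 2 (0.37 log units; beyond the scatter), was modest and involved an insertion of a sulfur link rather than an exchange of one ring for another, so it does not bear directly on the change at hand.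

Compound 4 `CS(=O)(=O)c1cc(C(=O)N=C(N)N)c(Cl)cc1-n1ccnc1` differs from compound 3 by 1H-imidazol-1-yl in place of (pyridin-3-yl)oxy on an aromatic carbon. For the measured compounds named here, no measured pair informs this exchange, so the expectation rests on compound 3 alone. The step from compound 3 to compound 4 in this assay is estimated to be small, a 1.3-fold higher number from compound 3 to compound 4 (0.13 log units; within the scatter), with no direction that can be supported by the data. Compound 4 is therefore expected to give 70 nM in this assay, with a range of 22 nM to 220 nM.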

Compound 4, half-maximal inhibitory concentration: 130 nM
Compound 4: the middle estimate sits 1.9-fold (0.27 log units) below what was measured; low and high end bracket the measured number.
By their numbers in this assay, from the lowest: compound 2; then compounds 1 and 3 (each within the scatter of the next); then compound 4.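

In this assay, the exchange at this place, ortho to a methylsulfonyl group, gave a 2.5-fold higher number from compound 3 to compound 4 (0.40 log units; beyond the scatter), so the two aromatic groups are not interchangeable here. The (pyridin-3-yl)oxy group that leaves and the 1H-imidazol-1-yl group that enters have the same counts of hydrogen-bond donors and acceptors and neither carries a net charge, yet the numbers still separate, so those shared counts do not settle the reading at this position. No available evidence accounts for the rise.

This single exchange alters both the oxygen link and the ring, which leaves open which of the two carries the step. Also open, going by these compounds, is how a pyridin-3-yl ring attached without the oxygen, or a simple amine, would read at this place in this assay.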